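A Longer Amine Side Chain and Expected Stability

This account rests on a few compounds, and the source may have more. Where it says the series, first, only, none or still open, it means among the compounds named here.

Measured in an ADME assay on microsomes from liver (Homo sapiens) for metabolic stability, using NADPH, with a stated time of 10 min; a lower number here means that less of the compound is left, a higher number that more of the compound is left:
compound 1 `NCCCCN(C[C@@H]1Cc2ncccc2CN1)[C@H]1CCCc2cccnc21`: 98%
compound 2 `CN(C[C@H]1Cc2ncccc2CN1)[C@H]1CCCc2cccnc21`: 95%
compound 3 `NC(=O)NC/C=C\CN(C[C@H]1Cc2ncccc2CN1)[C@H]1CCCc2cccnc21`: 100%

Compound 2 stands at the low end of these three numbers, but compound 1 and compound 3 both lie within the usual scatter of it, so the three compounds cannot be told apart in this assay.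

Compound 4 `CN(C)CCCCN(C[C@H]1Cc2ncccc2CN1)[C@H]1CCCc2cccnc21` differs from compound 2 by 3-(dimethylamino)propyl in place of hydrogen on a saturated chain carbon bound to an amine nitrogen. Within the data shown here, the one measured step that bears on this is the similar growth on the same carbon, a number 5 percentage points higher from compound 2 to compound 3 (within the scatter), which lay within the scatter. A step of the same kind, within the scatter, is therefore expected here: a number 1 percentage points higher from compound 2 to compound 4 (within the scatter). Compound 4 is expected to give 96%, between 88% and 100%.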

Compound 4, percent of the compound remaining: 100%
Estimate against measurement, compound 4: 4 percentage points below; low and high end bracket the measured number.
By their numbers in this assay, from the lowest: compounds 2, 1, 3 and 4 (each within the scatter of the next).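

With 3-(dimethylamino)propyl on this saturated chain carbon bound to an amine nitrogen, this assay shows a number 5 percentage points higher from compound 2 to compound 4 (within the scatter). Exchanging the group of 7 heavy atoms for this group of 6, which has no oxygen, gives no change at the digits printed from compound 3 to compound 4 (within the scatter), so two different chains at this position cannot be told apart in this read-out. No measurement shown here accounts for these numbers.

Still open, as far as these compounds go, is whether a carboxylic acid at the end of the chain, or a much longer chain, would give a number beyond the scatter of compound 2.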